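The compounds below may be only part of what the source reports. "The series", "measured", "known", "first", "only" and "open" are said of these compounds alone.

Compound 1 `COc1ccc(C(=O)CCN2CCN(c3ccc(F)cc3)CC2)cc1OC`: 175000 nM
Compound 2 `COc1ccc(C(=O)CCN2CCN(c3ccc(C(F)(F)F)cc3)CC2)cc1OC`: 243000 nM
Compound 3 `O=C(CCN1CCN(c2ccc(F)cc2)CC1)c1ccc(Br)cc1`: 99500 nM

Of the compounds shown here, three have been tested in an ADME assay on Vero cells (Chlorocebus sabaeus) for cytotoxicity, read by resazurin assay, with a stated time of 72 h; a higher number here means a weaker inhibitor, a lower number a stronger inhibitor. Compound 1 gives 175000 nM, and compound 2 gives 243000 nM. Compound 2 differs from compound 1 by trifluoromethyl in place of fluoro on an aromatic carbon, and the step is a 1.4-fold higher number from compound 1 to compound 2 (0.14 log units; within the scatter). Compound 3, which gives 99500 nM, has a different core; the difference between the core of compound 3 and the core of compound 1 is not broken down here. Compound 4 `O=C(CCN1CCN(c2ccc(C(F)(F)F)cc2)CC1)c1ccc(Br)cc1` is not yet measured in this assay. It differs from compound 3 by trifluoromethyl in place of fluoro on an aromatic carbon, the same change as from compound 1 to compound 2. The step from compound 3 to compound 4 is expected to be a 1.4-fold higher number from compound 3 to compound 4 (0.15 log units; within the scatter), because the earlier step was a 1.4-fold higher number from compound 1 to compound 2 (0.14 log units; within the scatter). Compound 4 is therefore estimated at 140000 nM, between 70000 nM and 280000 nM.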

Compound 4, half-maximal inhibitory concentration: 78800 nM
For compound 4 the middle estimate is 1.8-fold (0.25 log units) above the measured one; low and high end bracket the measured number.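

In this assay, trifluoromethyl in place of fluoro on an aromatic carbon gives a 1.3-fold lower number from compound 3 to compound 4 (0.10 log units; within the scatter), and the two cores show no difference in how they take this change: the same change on two cores in this assay, a 1.4-fold higher number (0.14 log units; within the scatter) from compound 1 to compound 2 and a 1.3-fold lower number (0.10 log units; within the scatter) from compound 3 to compound 4, 1.8-fold (0.24 log units) apart, within the scatter of two such steps. This shows that on these two cores the change leaves the number within the scatter, but it gives the change no direction and says nothing about any other core. Among the compounds shown here, of a different kind is 4-bromophenyl in place of 3,4-dimethoxyphenyl on a carbonyl carbon, which gives a 3.1-fold lower number from compound 2 to compound 4 (0.49 log units; beyond the scatter), a single step with no second pair to set beside it.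

The compounds shown leave open how a nitrile, a carboxylic acid or an amine would read in place of fluoro or trifluoromethyl. They also leave open whether the same holds with a longer chain on the carbonyl.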